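Compound 3 to compound 4 in a limit-bound series

A few compounds are considered here, and "the series" means these few. Any claim that something is new, unique, unknown or untested is made for them only; others in the source may bear on it.

In a functional assay on NALM-6 cells (Homo sapiens) for cytotoxicity, with a stated time of 72 h (on this read-out lower numbers stand for an effect already at smaller amounts and higher numbers for an effect only at larger amounts of compound), compound 1 `C=C[C@@](C)(/C=C/c1ccc(O)cc1)CCC=O` gives > 43400 nM as a limit. Compound 2 `C=C[C@@](C)(/C=C/c1ccc(O)cc1)CCCO` gives > 43400 nM as a limit too. Compound 3 `C=C[C@@](C)(/C=C/c1ccc(O)cc1)CC/C=C/C#N` gives > 43400 nM which is again a limit. Going by the values given here, compound 3 therefore has no number of its own, and the series so far comes down to the limit of > 43400 nM in this assay, at which 3 of the 3 values shown sit, with nothing that ranks one compound against another.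

The change to compound 4 `C=C[C@@](C)(/C=C/c1ccc(O)cc1)CC/C=C(C)/C=N/N` is a group of 6 heavy atoms (4 carbon, 2 nitrogen; no ring) in place of a group of 4 heavy atoms (3 carbon, 1 nitrogen; no ring), on a saturated chain carbon, three bonds along the chain from two double-bonded chain carbons and it falls at the one place already varied. Among the compounds with values here, three measured steps bear on it: a step that the two limits leave unreadable from compound 1 to compound 2 and a step that the two limits leave unreadable from compound 1 to compound 3 and a step that the two limits leave unreadable from compound 2 to compound 3 are all the evidence there is. None of them gives a size, so no measured direction carries over to the new group. The likeliest report in this assay is a further limit, with a number close under it as the alternative. The step is expected to be an at least 1.0-fold lower number from compound 3 to compound 4 (0.03 log units; that floor lies within the scatter) in this estimate, with only a weak lean towards lower numbers. For compound 4 the estimate is 40000 nM with an expected range from 12000 nM to 80000 nM in this read-out.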

Compound 4, half-maximal effective concentration: > 43400 nM
Compound 4 was reported as a limit (the forecaster's own chance of this, stated with the estimate: 65%); middle value at least 1.0-fold (0.03 log units) from the limit.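

In this assay compound 4 gives > 43400 nM, which is a limit. No step among compound 1, compound 2, compound 3 and compound 4 can be read, and the series rests on one shared limit: the limit of > 43400 nM in this assay, at which 4 of the 4 values shown sit.

The compounds shown leave open whether any group at this place on the shared core gives a measurable value.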